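This account rests on a few compounds, and the source may have more. Where it says the series, first, only, none or still open, it means among the compounds named here.

For the measured compounds named here, in a functional assay on U-251 cells (Homo sapiens) for cytotoxicity, read by XTT assay, with a stated time of 72 h (on this read-out lower numbers stand for stronger inhibition and higher numbers for weaker inhibition), compound 1 `C/C=C(/C)C(=O)O[C@@H]1C(=O)C(CO)=C[C@@H](OC(=O)/C(C)=C\C)[C@H]1C(C)C` gives 3000 nM and compound 2 `C/C=C(/C)C(=O)O[C@@H]1C=C(CO)C(=O)[C@@H](OC(=O)[C@]2(C)O[C@@H]2C)[C@@H]1C(C)C` gives 2900 nM, so compound 2 stands level with the only other measured compound. Compound 3 `C/C=C(/C)C(=O)O[C@@H]1C=C(CO)C(=O)[C@@H](OC(=O)[C@](C)(O)[C@@H](C)Cl)[C@@H]1C(C)C` differs from compound 2 by 2-chloro-1-hydroxy-1-methylpropyl in place of 2,3-dimethyloxiran-2-yl on a carbonyl carbon. Going by the values given here, one measured step bears on this place on a carbonyl carbon: a 1.0-fold lower number from compound 1 to compound 2 (0.01 log units; within the scatter). It is a single step and involves no open-chain group bearing chlorine and hydroxy, so the support is thin. No change beyond the scatter is expected in this assay. The expected step is a 1.0-fold higher number from compound 2 to compound 3 (0.01 log units; within the scatter). For compound 3 the estimated value is 3000 nM, with an expected range of 1300 nM to 7000 nM.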

Compound 3, half-maximal inhibitory concentration: 2100 nM
Compound 3: the middle estimate sits 1.4-fold (0.15 log units) above what was measured; the range from low to high includes it.
By their numbers in this assay, from the lowest: compounds 3, 2 and 1 (each within the scatter of the next).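

In this assay, 2-chloro-1-hydroxy-1-methylpropyl on this carbonyl carbon gives a 1.4-fold lower number from compound 2 to compound 3 (0.14 log units; within the scatter) and a 1.4-fold lower number from compound 1 to compound 3 (0.15 log units; within the scatter). Both steps lie within the scatter, so this open chain, which carries chlorine and a hydrogen-bond donor, stands level with 2,3-dimethyloxiran-2-yl and 1-methylprop-1-en-1-yl, and the three-membered ring is not needed to hold the value. Nothing given here explains why the number stays level across these groups.

Going by these compounds, whether an amine, a carboxylic acid or a longer chain at this place would move the value beyond the scatter remains open.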